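Triazole substituent swap on a shared furanone core

The source may report more compounds than this note shows. Statements on the series, on what has been measured and on what is new or still open speak of the compounds shown alone.

Among the measured compounds shown here, compound 1 `O=C1O[C@H]([C@@H](O)Cn2cc(-c3cccc(O)c3)nn2)C(OCc2ccccc2)=C1OCc1ccccc1` and compound 2 `COc1ccccc1-c1cn(C/C=C2\OC(=O)C(OCc3ccccc3)=C2OCc2ccccc2)nn1` are the two measured members of this set. In a functional assay on SW-620 cells (Homo sapiens) for antiproliferative activity, read by MTT assay, with a stated time of 72 h (on this read-out higher numbers stand for weaker inhibition and lower numbers for stronger inhibition), compound 1 gives > 100000 nM, which is a limit of the assay and not a number. Compound 2 likewise gives > 100000 nM in this assay, again a limit. Compound 1 therefore stands at the limit of > 100000 nM in this assay, at which 2 of the 2 values shown sit, with no measured number to rank it against anything. For the measured compounds named here, no pair of measured compounds differs in one place, so no measured step is available, and of compound 1 and compound 2 it can only be said that both sit at the limit.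

The unmeasured compound 3 `O=C1O[C@H]([C@@H](O)Cn2cc(CCCCl)nn2)C(OCc2ccccc2)=C1OCc1ccccc1` is reached from compound 1 by 3-chloropropyl in place of 3-hydroxyphenyl on an aromatic carbon. Nothing measured here shows that a group at this position changes the read-out, so the step of a number no higher from compound 1 to compound 3 (the limit leaves the size open) from compound 1 to compound 3 is expected to be none beyond the scatter, with the result most probably reported as a limit again. For compound 3 the estimate in this assay is 100000 nM, within a range of 30000 nM to 300000 nM.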

Compound 3, half-maximal inhibitory concentration: 68500 nM
Compound 3: the middle estimate sits 1.5-fold (0.16 log units) above what was measured, and the stated range covers the measured number.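

In this assay, among the compounds shown here, compound 3 gives 68500 nM, the only actual number in the set, so a measurable value is possible with 3-chloropropyl on this aromatic carbon of the five-membered aromatic ring, where no aromatic ring is carried by the substituent. On these data alone, exchanging 3-hydroxyphenyl for 3-chloropropyl gives an at least 1.4-fold lower number from compound 1 to compound 3 (0.16 log units; that floor lies within the scatter), so the change cannot yet be called real, and its true size remains open. Compound 1 stands at > 100000 nM, a limit and not a number, and the step therefore gives only a floor; compound 3 is the one compound shown outside this shared limit: the limit of > 100000 nM in this assay, at which 2 of the 3 values shown sit.

As far as these compounds go, it remains open whether the chlorine or the three-carbon chain matters, and a plain propyl group, a longer chloroalkyl chain or a terminal amine on the chain would separate these parts. From the compounds shown here alone, it is also open whether any group at this carbon can move the number well beyond the scatter in this assay.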